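The compounds below may be only part of what the source reports. "The series", "measured", "known", "first", "only" and "open" are said of these compounds alone.

Measured compounds:
- compound 1 `Cc1cc(-c2ccccc2)n(/C(N)=N/S(=O)(=O)c2cc(C)c(Cl)cc2SCc2cccc3ccccc23)n1`: 7000 nM
- compound 2 `Cc1cc(S(=O)(=O)/N=C(\N)n2nccc2-c2ccccc2)c(SCc2cccc(Cl)c2)cc1Cl`: 7000 nM
- compound 3 `Cc1cc(-c2ccccc2)n(/C(N)=N/S(=O)(=O)c2cc(C)c(Cl)cc2SCc2cccc(Cl)c2)n1`: 18000 nM

In a functional assay on HCT-116 cells (Homo sapiens) for cytotoxicity, read by MTT assay, with a stated time of 72 h (a lower number here means a stronger inhibitor, a higher number a weaker inhibitor), compound 1 gives 7000 nM. Compound 2 gives the same number at the digits reported, so the two stand level and together give the lowest numbers of the three. Compound 3 gives 18000 nM, higher by a 2.6-fold higher number from compound 1 to compound 3 (0.41 log units; beyond the scatter) and, on the other route, by a 2.6-fold higher number from compound 2 to compound 3 (0.41 log units; beyond the scatter).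

Compound 4 `Cc1cc(-c2ccccc2)n(/C(N)=N/S(=O)(=O)c2cc(C)c(Cl)cc2SCc2ccccc2C)n1` differs from compound 1 by 2-methylphenyl in place of naphthalen-1-yl on a saturated chain carbon bound to a sulfur. The step that bears on this change is a 2.6-fold higher number from compound 1 to compound 3 (0.41 log units; beyond the scatter), where the naphthalen-1-yl on the same chain carbon gave way to 3-chlorophenyl, a single six-membered ring, and the number rose modestly. The step of a 2.6-fold higher number from compound 2 to compound 3 (0.41 log units; beyond the scatter) concerns a methyl on an aromatic carbon elsewhere in the core and does not touch the group on the sulfur-bound carbon. Compound 4 likewise carries a single six-membered ring there, so a modest rise beyond the scatter, in the same direction, is expected, though a smaller one cannot be ruled out from one step. Compound 4 is therefore estimated at 12000 nM in this assay, between 5000 nM and 30000 nM, a step of a 1.7-fold higher number from compound 1 to compound 4 (0.23 log units; within the scatter).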

Compound 4, half-maximal inhibitory concentration: 42000 nM
Beside the measured number, compound 4's estimate is 3.5-fold (0.54 log units) below it; measured number above the stated range.
By their numbers in this assay, from the lowest: compounds 1 and 2 (each within the scatter of the next); then compound 3; then compound 4.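

In this assay the new step shows that the group on a saturated chain carbon bound to a sulfur does more than separate two aromatic rings from one: the step between two single-ring groups, 3-chlorophenyl and 2-methylphenyl, gives a 2.3-fold higher number from compound 3 to compound 4 (0.37 log units; beyond the scatter) and lies beyond the scatter. Replacing naphthalen-1-yl with 2-methylphenyl gives a 6.0-fold higher number from compound 1 to compound 4 (0.78 log units; beyond the scatter) and places compound 4 highest of the three compounds that differ only at this place, so the count of aromatic rings alone does not set the number in this small set, and all three values remain weak in absolute terms. No measurement at hand accounts for either step.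

As far as these compounds go, the methyl on an aromatic carbon has been read only with 3-chlorophenyl on the chain, through a 2.6-fold higher number from compound 2 to compound 3 (0.41 log units; beyond the scatter), so whether it would move the number in the same way with 2-methylphenyl or naphthalen-1-yl stays open. Also open, from the compounds shown here alone, is how this position responds to a group of another kind on the chain carbon, such as an amine, a carboxylic acid or a longer chain ending in phenyl.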